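The compounds below may be only part of what the source reports. "The series", "measured", "known", "first", "only" and "open" are said of these compounds alone.

Compound 1 `CN(C(=O)NC(=O)c1ccccc1F)c1nc(C(F)(F)F)c(C(=O)N/N=C/c2cc(C(F)(F)F)cc(C(F)(F)F)c2)s1` is the starting point of this account. Going by the values given here, in a functional assay on A549 cells (Homo sapiens) for inhibition, read by MTT assay, with a stated time of 72 h (a higher number here means a weaker inhibitor, a lower number a stronger inhibitor), compound 1 gives 5.43 ug/mL, the lowest of the three numbers measured so far. Compound 2 `CN(C(=O)NC(=O)c1ccc(F)c(F)c1)c1nc(C(F)(F)F)c(C(=O)N/N=C/c2cc(C(F)(F)F)cc(C(F)(F)F)c2)s1` gives 5.47 ug/mL in this assay, and the step of a 1.0-fold higher number from compound 1 to compound 2 (0.00 log units; within the scatter) shows that exchanging the fluorinated phenyl on the carbonyl carbon changes nothing beyond the scatter. Compound 3 `CN(C(=O)NC(=O)c1ccccc1F)c1nc(C(F)(F)F)c(C(=O)N/N=C/c2cccc(C(F)(F)F)c2)s1` gives 19.5 ug/mL, and the step of a 3.6-fold higher number from compound 1 to compound 3 (0.56 log units; beyond the scatter) shows that removing one trifluoromethyl from the aromatic ring of the hydrazone part weakens inhibition modestly.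

Compound 4 `CNc1nc(C(F)(F)F)c(C(=O)N/N=C/c2cc(C(F)(F)F)cc(C(F)(F)F)c2)s1` is the next compound to be measured. Its difference from compound 1 is hydrogen in place of ((2-fluorophenyl)carbonyl)carbamoyl on a nitrogen on an aromatic ring. Neither measured step bears directly on this change: the step from compound 1 to compound 2 touches the same part of the molecule but only alters its substitution, while the step from compound 1 to compound 3 concerns a different region. Among the compounds with values here, no step here removes a whole group of that size. The expectation for compound 4 is therefore a weaker inhibitor than compound 1, with considerable uncertainty, and the step of a 2.8-fold higher number from compound 1 to compound 4 (0.44 log units; beyond the scatter) is expected. Compound 4 is thus estimated at 15 ug/mL, within a range of 4 ug/mL to 60 ug/mL.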

Compound 4, half-maximal inhibitory concentration: > 100 ug/mL
Compound 4 was reported as a limit; the forecaster's own chance of this, stated with the estimate: 10%; at least 6.6-fold (0.82 log units) between middle value and limit.
By their numbers in this assay, from the lowest: compounds 1 and 2 (each within the scatter of the next); then compound 3. At a limit, above all of these: compound 4.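

In this assay, the earlier change within the ((2-fluorophenyl)carbonyl)carbamoyl group altered only its fluorine pattern and stayed within the scatter (a 1.0-fold higher number from compound 1 to compound 2 (0.00 log units; within the scatter)), so it could not show whether the group as a whole matters. Replacing the entire group with hydrogen on the nitrogen on an aromatic ring answers that question, giving a large step (an at least 18-fold higher number from compound 1 to compound 4 (1.26 log units; beyond the scatter)) and showing that, on the core of compound 1, inhibition in this assay depends on a substituent at this nitrogen even though the two fluorine patterns tried there read alike. The reading for compound 4 is a limit and not a number, so the step has a lower bound only: the limit of > 100 ug/mL in this assay, at which 1 of the 4 values shown sits.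

The compounds shown leave open which part of the group is needed, for instance whether a plain carbamoyl or a small acetyl group on this nitrogen would restore inhibition, or whether the unsubstituted benzoyl ring would do as well as the fluorinated ones. They also leave open whether a longer chain between the urea and the phenyl ring would be tolerated at this position.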